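Replacing pyridin-4-yl with 3-fluorophenyl on a carbonyl carbon

The source may hold more compounds than are shown below. What is called first, only, known or untested is meant among the compounds shown, and "the series" means these compounds.

Of the compounds shown here, three that share one core have been tested so far in an ADME assay on Vero cells (Chlorocebus sabaeus) for cytotoxicity, read by MTT assay, with a stated time of 48 h (a higher number here means a weaker inhibitor, a lower number a stronger inhibitor), and each gave only a limit. Compound 1 (`CC(C)C(=O)OC1CCC(CN2CCN(c3cc(=O)c4cc(C(F)(F)F)cc([N+](=O)[O-])c4s3)CC2)CC1`) reads > 64 ug/mL as a limit of the assay and not as a number. Compound 2 (`CCCC(=O)OC1CCC(CN2CCN(c3cc(=O)c4cc(C(F)(F)F)cc([N+](=O)[O-])c4s3)CC2)CC1`) reads > 64 ug/mL and this too is a limit. Compound 3 (`O=C(OC1CCC(CN2CCN(c3cc(=O)c4cc(C(F)(F)F)cc([N+](=O)[O-])c4s3)CC2)CC1)c1ccncc1`) reads > 64 ug/mL and this is again a limit, so it stands level with the other two on the numbers shown (the limit of > 64 ug/mL in this assay, at which 3 of the 3 values shown sit).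

Compound 4 (`O=C(OC1CCC(CN2CCN(c3cc(=O)c4cc(C(F)(F)F)cc([N+](=O)[O-])c4s3)CC2)CC1)c1cccc(F)c1`) is still unmeasured. It carries 3-fluorophenyl in place of pyridin-4-yl on a carbonyl carbon.

The measured steps that bear on this change sit on that same carbonyl carbon. They are a step that the two limits leave unreadable from compound 1 to compound 2 and then a step that the two limits leave unreadable from compound 1 to compound 3 and finally a step that the two limits leave unreadable from compound 2 to compound 3 in this short series. None has a readable size, but propyl, isopropyl and pyridin-4-yl all leave the reading at the same limit.

The expected step (a step that the limit leaves unreadable from compound 3 to compound 4) in this assay is estimated to stay within the scatter, with no direction favoured. The estimate for compound 4 is 70 ug/mL with an expected range from 40 ug/mL to 128 ug/mL and the reading may well be a limit once more.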

Compound 4, half-maximal inhibitory concentration: > 64 ug/mL
Compound 4: no number, only a limit; the forecaster's own chance of this, stated with the estimate: 85%; the middle value is on the limit's open side.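

In this assay compound 4 reads > 64 ug/mL, which is a limit and not a number. No step between compound 4 and compound 1, compound 2 or compound 3 can be read, as all four sit at one limit: the limit of > 64 ug/mL in this assay, at which 4 of the 4 values shown sit.

The compounds shown leave open whether these groups on the carbonyl carbon differ at all in this read-out, and what actual value any of the four compounds would give.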